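A few compounds are considered here, and "the series" means these few. Any claim that something is new, unique, unknown or untested is made for them only; others in the source may bear on it.

Compound 1 `COc1ccc(C(=O)c2cc(OC)c(OC)c(OC)c2)cc1NC(=O)/C=C/c1cc(OC)c(OC)c(OC)c1` carries the shared core with a 3,4,5-trimethoxyphenyl on the double-bonded chain carbon. Among the measured compounds shown here, in a functional assay on HeLa cells (Homo sapiens) for cytotoxicity, read by MTT assay, with a stated time of 72 h (on this read-out lower numbers stand for stronger inhibition and higher numbers for weaker inhibition), compound 1 gives 1500 nM, the second highest of the three numbers measured so far. Compound 2 `COc1cccc(/C=C/C(=O)Nc2cc(C(=O)c3cc(OC)c(OC)c(OC)c3)ccc2OC)c1` gives 3100 nM, and the step from compound 1 to compound 2 is a 2.1-fold higher number from compound 1 to compound 2 (0.32 log units; beyond the scatter). Compound 3 `COc1ccc(C(=O)c2cc(OC)c(OC)c(OC)c2)cc1NC(=O)/C=C/c1ccc(F)cc1` gives 60 nM, reached by a step of a 25-fold lower number from compound 1 to compound 3 (1.40 log units; beyond the scatter), and from compound 2 to compound 3 the step is a 52-fold lower number from compound 2 to compound 3 (1.71 log units; beyond the scatter).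

Compound 4 `COc1cc(C(=O)c2cc(OC)c(OC)c(OC)c2)cc(NC(=O)/C=C/c2cc(OC)c(OC)c(OC)c2)c1OC` differs from compound 1 by methoxy in place of hydrogen on an aromatic carbon. Each of the three measured steps alters the aryl group on the double-bonded chain carbon, whereas the change to compound 4 leaves that group untouched and puts a methoxy on an aromatic carbon of the core. For the measured compounds named here, no measured step therefore bears directly on this change, and the numbers at hand give no ground for expecting a move in either direction. The account expects a step from compound 1 to compound 4 of no change at the digits printed from compound 1 to compound 4 (within the scatter), that is, nothing beyond the scatter. For compound 4 the estimate in this assay is 1500 nM, with a range from 500 nM to 4500 nM.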

Compound 4, half-maximal inhibitory concentration: 2500 nM
The estimate for compound 4 lay 1.7-fold (0.22 log units) below the measured number; measured number inside the range.
By their numbers in this assay, from the lowest: compound 3; then compounds 1, 4 and 2 (each within the scatter of the next, the first and the last beyond it).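

Among the compounds shown here, compound 4 gives the first reading at a position on the core rather than on the aryl group of the double-bonded chain carbon: in this assay, methoxy in place of hydrogen on an aromatic carbon, ortho to a methoxy group and meta to two large groups, gives a 1.7-fold higher number from compound 1 to compound 4 (0.22 log units; within the scatter) and so stays within the usual scatter. This contrasts with the exchange of the aryl group, where a 25-fold lower number from compound 1 to compound 3 (1.40 log units; beyond the scatter) shows how far the number can move with a change at that other place, so on the 3,4,5-trimethoxyphenyl background the added methoxy leaves no measurable mark at this position. No measurement bearing on the reason for this result is available.

As far as these compounds go, it remains open whether the same methoxy would also leave the number within the scatter on the 4-fluorophenyl background of compound 3, where the number is far lower and any step might read differently. From the compounds shown here alone, it also remains open how this aromatic carbon would respond to a different group, such as an amine, a hydroxyl or a carboxylic acid, in place of the hydrogen.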